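Swapping the methoxy-bearing ring for a difluoro ring

The compounds below may be only part of what the source reports. "The series", "measured", "known", "first", "only" and "open" are said of these compounds alone.

Compound 1 has the structure `COc1ccc(/C=C/C(=O)c2ccc(OCCCSC(=S)N3CCN(C)CC3)cc2)cc1`. In a functional assay on MGC-803 cells (Homo sapiens) for inhibition, read by MTT assay, with a stated time of 72 h (a higher number here means a weaker inhibitor, a lower number a stronger inhibitor), compound 1 gives 19400 nM. A second compound, compound 2 with the structure `COc1cc(/C=C/C(=O)c2ccc(OCCCSC(=S)N3CCCC3)cc2)cc(OC)c1OC`, differs from it in more than one place; in this assay compound 2 gives 14500 nM, and the two numbers lie within the usual scatter of each other, so neither can be called the weaker or the stronger inhibitor.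

The new compound, compound 3 with the structure `CN1CCN(C(=S)SCCCOc2ccc(C(=O)/C=C/c3cc(F)cc(F)c3)cc2)CC1`, is built from compound 1 by one change: 3,5-difluorophenyl in place of 4-methoxyphenyl on a double-bonded chain carbon bound to a double-bonded chain carbon. No pair of measured compounds shows this kind of change, so its size and direction are not known from the data shown here. Without such a precedent, the expected step of a 1.3-fold lower number from compound 1 to compound 3 (0.11 log units; within the scatter) is small and lies within the scatter. Compound 3 is therefore estimated at 15000 nM, with a range from 6000 nM to 40000 nM.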

Compound 3, half-maximal inhibitory concentration: 16300 nM
Compound 3: the middle estimate sits 1.1-fold (0.04 log units) below what was measured, and the stated range covers the measured number.
By their numbers in this assay, from the lowest: compounds 2, 3 and 1 (each within the scatter of the next).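

In this assay, within the data shown here, putting 3,5-difluorophenyl in place of 4-methoxyphenyl on a double-bonded chain carbon bound to a double-bonded chain carbon gives a 1.2-fold lower number from compound 1 to compound 3 (0.08 log units; within the scatter) and this is the first step read at this position. The swap removes the one hydrogen-bond acceptor counted on the leaving group and keeps the heavy-atom count the same, yet compound 1 and compound 3 cannot be told apart in this measurement. No separate measurement is available to explain this result.

On these data alone, whether a phenyl ring carrying an amine or a carboxylic acid at this place would give a number beyond the scatter from compound 1 remains open. So does whether the same swap would read alike in a compound with a longer chain leading to the sulfur.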